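Cyano in place of methyl on a thiazole amide

The source may report more compounds than this note shows. Statements on the series, on what has been measured and on what is new or still open speak of the compounds shown alone.

Compound 1, `CC(C)[C@H](C(=O)NC(C)(C)C)c1ccc(Cl)cc1`, gives > 100000 nM in a functional assay on CHO cells for agonist activity at Free fatty acid receptor 2 (Homo sapiens), read by cAMP accumulation; on this read-out higher numbers stand for weaker inhibition and lower numbers for stronger inhibition; this is a limit of the assay, not a number.
Compound 2, `CC(C)[C@H](C(=O)Nc1nncs1)c1ccc(Cl)cc1`, gives 12000 nM in this assay.
Compound 3, `Cc1csc(NC(=O)[C@H](c2ccc(Cl)cc2)C(C)C)n1`, gives 1400 nM in this assay.

Compound 3 holds the lowest number shown; the nearest is an 8.6-fold lower number from compound 2 to compound 3 (0.93 log units; beyond the scatter). Compound 4, `CC(C)[C@H](C(=O)Nc1ncc(C#N)s1)c1ccc(Cl)cc1`, differs from compound 3 only in 5-cyano-1,3-thiazol-2-yl in place of 4-methyl-1,3-thiazol-2-yl on an amide-type nitrogen. Among the compounds with values here, the steps that bear on this place are an at least 8.3-fold lower number from compound 1 to compound 2 (0.92 log units; beyond the scatter), an at least 71-fold lower number from compound 1 to compound 3 (1.85 log units; beyond the scatter) and an 8.6-fold lower number from compound 2 to compound 3 (0.93 log units; beyond the scatter): all three came from exchanging the whole group on the amide nitrogen, and none tested a substituent swap on the same thiazole ring. For compound 4 a step no larger than the scatter, or a slight rise, is therefore expected, a 1.4-fold higher number from compound 3 to compound 4 (0.15 log units; within the scatter). Compound 4 is estimated at 2000 nM, within 400 nM to 10000 nM.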

Compound 4, half-maximal inhibitory concentration: 2000 nM
Beside the measured number, compound 4's estimate shows no gap at the digits printed; the measured number falls inside the stated range.
By their numbers in this assay, from the lowest: compounds 3 and 4 (each within the scatter of the next); then compound 2. At a limit, above all of these: compound 1.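

In this assay, compounds 3 and 4 give the only comparison shown between two substituted thiazoles on the amide-type nitrogen, and it shows a 1.4-fold higher number from compound 3 to compound 4 (0.15 log units; within the scatter). 5-Cyano-1,3-thiazol-2-yl also keeps a clear margin over 1,3,4-thiadiazol-2-yl, with a 6.0-fold lower number from compound 2 to compound 4 (0.78 log units; beyond the scatter). The step against tert-butyl, an at least 50-fold lower number from compound 1 to compound 4 (1.69 log units; beyond the scatter), starts from a limit of the assay, not a number.

On these data alone, what an amine or a carboxylic acid would give in place of the nitrile on this thiazole remains open.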